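Swapping a dimethylamino chain end for a methylpiperazine

A few compounds are considered here, and "the series" means these few. Any claim that something is new, unique, unknown or untested is made for them only; others in the source may bear on it.

Of the compounds shown here, three built on one shared core have been tested in a functional assay on MCF7 cells (Homo sapiens) for cytotoxicity, read by MTT assay, with a stated time of 72 h; a higher number here means a weaker inhibitor, a lower number a stronger inhibitor. Compound 1 `O=C1c2c[n+]([O-])c3ccccc3c2C(=O)c2c1c1ccccc1n2Cc1cn(C[C@@H](O)CO)nn1` gives 600 nM, while compound 2 `O=C1c2c[n+]([O-])c3ccccc3c2C(=O)c2c1c1ccccc1n2Cc1cn(CC(O)CO)nn1` gives 1110 nM, a pair showing a 1.9-fold higher number from compound 1 to compound 2 (0.27 log units; within the scatter) and marked by the fact that one of compounds 1 and 2 is drawn with a defined configuration and the other without, at the place where they differ. Compound 3 `CN(C)CCCCn1c2c(c3ccccc31)C(=O)c1c[n+]([O-])c3ccccc3c1C2=O` gives 220 nM, the lowest of the three numbers, reached through a 2.7-fold lower number from compound 1 to compound 3 (0.44 log units; beyond the scatter) and a 5.0-fold lower number from compound 2 to compound 3 (0.70 log units; beyond the scatter). Compound 4 `CN1CCN(CCCn2c3c(c4ccccc42)C(=O)c2c[n+]([O-])c4ccccc4c2C3=O)CC1` is not yet measured; it differs from compound 3 by 4-methylpiperazin-1-yl in place of (dimethylamino)methyl on a saturated chain carbon, three bonds along the chain from an aromatic nitrogen. Going by the values given here, no measured step exchanges one amine for another, so none bears directly on this change; the modest steps toward compound 3 concern a different part of the chain. The expected step is therefore a 1.4-fold higher number from compound 3 to compound 4 (0.13 log units; within the scatter), within the scatter. Compound 4 is expected to give about 300 nM, between 120 nM and 800 nM.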

Compound 4, half-maximal inhibitory concentration: 220 nM
For compound 4 the middle estimate is 1.4-fold (0.13 log units) above the measured one, and the stated range covers the measured number.
By their numbers in this assay, from the lowest: compounds 3 and 4 (each within the scatter of the next); then compounds 1 and 2 (each within the scatter of the next).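

Replacing 4-(dimethylamino)butyl with 3-(4-methylpiperazin-1-yl)propyl, a ring amine on a shorter chain, leaves this assay unmoved, with no change at the digits printed from compound 3 to compound 4 (within the scatter). The advantage over the 1-(2,3-dihydroxypropyl)-1H-1,2,3-triazol-4-yl compounds therefore does not depend on the dimethylamino end alone, as the piperazine shows a 5.0-fold lower number from compound 2 to compound 4 (0.70 log units; beyond the scatter) and a 2.7-fold lower number from compound 1 to compound 4 (0.44 log units; beyond the scatter). Nothing in the available evidence accounts for this result. Chain length and amine changed together here, so their separate contributions remain unknown. A 4-(4-methylpiperazin-1-yl)butyl chain or a morpholine end would help separate them.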